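This account rests on a few compounds, and the source may have more. Where it says the series, first, only, none or still open, it means among the compounds named here.

Measured in a physicochemical assay for solubility, at pH 7; on this read-out lower numbers stand for lower solubility and higher numbers for higher solubility:
- Compound 1 `NC(=O)c1cc(-c2ccnc(N)n2)[nH]c1-c1cc(C(F)(F)F)ccc1Cl`: 159000 nM
- Compound 2 `CCc1ccc(Cl)cc1-c1[nH]c(-c2ccnc(N)n2)cc1C(N)=O`: 200000 nM

Compound 2 stands level with compound 1, since their two values lie within the usual scatter of each other. Compound 3 `CCc1ccc(C(F)(F)F)cc1-c1[nH]c(-c2ccnc(N)n2)cc1C(N)=O` differs from compound 2 in one place: trifluoromethyl in place of chloro on an aromatic carbon. Trifluoromethyl takes the place of chloro on an aromatic carbon, para to an ethyl group. For the measured compounds named here, no measured pair shows this exchange alone. Compound 1 also carries trifluoromethyl and gives 159000 nM, so no step beyond the scatter is expected in this assay, perhaps a slight fall. The expected change is a 1.3-fold lower number from compound 2 to compound 3 (0.12 log units; within the scatter). Compound 3 is estimated at 150000 nM, with an expected range of 70000 nM to 220000 nM.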

Compound 3, solubility: 182000 nM
For compound 3 the middle estimate is 1.2-fold (0.08 log units) below the measured one; measured number inside the range.
By their numbers in this assay, from the lowest: compounds 1, 3 and 2 (each within the scatter of the next).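

Trifluoromethyl in place of chloro on an aromatic carbon, para to an ethyl group, is now seen alone, and in this assay it stays level (a 1.1-fold lower number from compound 2 to compound 3 (0.04 log units; within the scatter)). Ethyl in place of chloro on an aromatic carbon also stays level (a 1.1-fold higher number from compound 1 to compound 3 (0.06 log units; within the scatter)), so neither exchange moves the read-out beyond the usual scatter. Nothing measured here explains why these values stay level. On these data alone, whether an amine or a carboxylic acid on this aromatic carbon would also stay level remains open, as does the effect of a longer chain in place of ethyl.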